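This account rests on a few compounds, and the source may have more. Where it says the series, first, only, none or still open, it means among the compounds named here.

In a physicochemical assay for lipophilicity, at pH 7.4 (a lower number here means a more polar compound, a higher number a more lipophilic compound), compound 1 `CNC(=O)c1cc(C(=O)NC2CC2)cc2c1OC[C@H]2c1cccc2[nH]ccc12` gives 3.5 as its reading. That lies within the scatter of compound 3 `CNC(=O)c1cc(C(=O)N[C@H]2[C@@H]3COC[C@@H]32)cc2c1O[C@H](CF)[C@H]2c1ccccc1` at 3.6 on this scale, and clearly apart from compound 2 `CNC(=O)c1cc(C(=O)N[C@H]2[C@@H]3COC[C@@H]32)cc2c1OC[C@H]2c1cccc2[nH]ccc12` at 3.1 on the same scale.

Compound 4 `CNC(=O)c1cc(C(=O)NC2CC2)cc2c1OC[C@H]2c1cccc(F)c1` keeps the core of compound 1 and makes one change: 3-fluorophenyl in place of 1H-indol-4-yl on a saturated ring carbon.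

For the measured compounds named here, only one measured step changes a single place (a number 0.40 log units lower from compound 1 to compound 2 (beyond the scatter)). It sits on an amide-type nitrogen, so it shows how large a one-place swap can be here but says nothing direct about this swap.

The nearest hint is a loose one. Compound 2, with 1H-indol-4-yl, reads 3.1 while compound 3, with phenyl and a fluoromethyl as well, reads 3.6 on this scale, but these two differ in more than one place.

A small upward move is therefore expected, possibly one that does not clear the scatter. The expected change is a number 0.20 log units higher from compound 1 to compound 4 (within the scatter) in this estimate. In this assay the estimate for compound 4 is 3.7 with the reading expected between 3.3 and 4.1.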

Compound 4, distribution coefficient: 3.7
Estimate against measurement, compound 4: no gap at the digits printed; low and high end bracket the measured number.
By their numbers in this assay, from the lowest: compound 2; then compounds 1, 3 and 4 (each within the scatter of the next).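

On the saturated ring carbon of the shared core, putting 3-fluorophenyl in place of 1H-indol-4-yl gives, in this assay, a number 0.20 log units higher from compound 1 to compound 4 (within the scatter). For the compounds shown here, this is the first measured one-place swap at this position, and although the entering group has no hydrogen-bond donor and one aromatic ring where the leaving group has one of each and two rings, the readings of the two compounds cannot be told apart, whereas the swap on the amide-type nitrogen gives a number 0.40 log units lower from compound 1 to compound 2 (beyond the scatter), a step beyond the scatter. Nothing measured here bears on what lies behind this result.

The compounds shown cover only these two aryl groups on that saturated ring carbon, so it stays open whether a group of another kind there, such as an aminomethyl group or a carboxylic acid on the phenyl ring, would give a step beyond the scatter. On these data alone, it also stays open whether the same exchange gives a similar step when the amide-type nitrogen carries the group found in compound 2.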